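From Isopropylamino to Butylamino on a Shared Core

The source may hold more compounds than are shown below. What is called first, only, known or untested is meant among the compounds shown, and "the series" means these compounds.

Compound 1 `CCCNC(=O)Nc1cccc2c1CN(C)CC2c1ccccc1` in a functional assay on the whole organism for inhibition of sodium-dependent dopamine transporter (Mus musculus) (on this read-out higher numbers stand for an effect only at larger amounts of compound and lower numbers for an effect already at smaller amounts), shows only a limit of the assay, > 120 mg/kg.
Compound 2 `CC(C)NCC(=O)Nc1cccc2c1CN(C)CC2c1ccccc1` in this assay gives about 30 mg/kg.

Compound 2 holds the only true number shown; the other value is a limit (the limit of > 120 mg/kg in this assay, at which 1 of the 2 values shown sits). Among the compounds with values here, the one measured step, an at least 4.0-fold lower number from compound 1 to compound 2 (0.60 log units; beyond the scatter), changed both the chain and its link to the carbonyl. Compound 3 `CCCCNCC(=O)Nc1cccc2c1CN(C)CC2c1ccccc1` differs from compound 2 by butyl in place of isopropyl on an amine nitrogen, a change of chain shape only. Within the data shown here, no measured step bears directly on it, so no step beyond the scatter is expected: no change at the digits printed from compound 2 to compound 3 (within the scatter). Compound 3 is therefore estimated at 30 mg/kg, between 12 mg/kg and 80 mg/kg.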

Compound 3, dose for half-maximal effect: 25 mg/kg
The estimate for compound 3 lay 1.2-fold (0.08 log units) above the measured number; low and high end bracket the measured number.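

Butyl in place of isopropyl on an amine nitrogen gives a 1.2-fold lower number from compound 2 to compound 3 (0.08 log units; within the scatter) in this assay and so leaves the dose unmoved at this position. (Butylamino)methyl in place of propylamino on a carbonyl carbon gives an at least 4.8-fold lower number from compound 1 to compound 3 (0.68 log units; beyond the scatter) and so shows the same direction as the earlier step with the isopropyl chain. Compound 1 shows only a limit of the assay, so this step has no exact size: the limit of > 120 mg/kg in this assay, at which 1 of the 3 values shown sits.

On these data alone, whether a longer chain such as hexyl, a cyclohexyl ring or a carboxylic acid on this amine nitrogen would keep the dose stays open.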